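This account rests on a few compounds, and the source may have more. Where it says the series, first, only, none or still open, it means among the compounds named here.

Measured so far in an ADME assay for permeability, using PAMPA, with a stated time of 30 min, at pH 7.4; on this read-out lower numbers stand for lower permeability and higher numbers for higher permeability:
compound 1 `COc1ccc(Cn2c(-c3ccccc3)c(-c3ccccc3)c3c(=N)n(CC4CCCO4)cnc32)cc1`: > 1000 10^-6 cm/s
compound 2 `N=c1c2c(-c3ccccc3)c(-c3ccccc3)n(Cc3ccccc3)c2ncn1CCCN1CCN(c2ccccc2)CC1`: > 1000 10^-6 cm/s
compound 3 `N=c1c2c(-c3ccccc3)c(-c3ccccc3)n(CC3CC3)c2ncn1CC1CCOCC1`: > 1000 10^-6 cm/s

Each of these three values is a limit of this assay, not a measured number. Compound 1 therefore stands at that limit, and so do the other two, as the limit of > 1000 10^-6 cm/s in this assay, at which 3 of the 3 values shown sit, shows. Within the data shown here, no pair of measured compounds differs in a single place, so no step size can be read from these data.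

Compound 4 `COc1ccc(Cn2c(-c3ccccc3)c(-c3ccccc3)c3c(=N)n([C@H]4CC[C@H](O)CC4)cnc32)cc1` differs from compound 1 in one place: 4-hydroxycyclohexyl in place of (oxolan-2-yl)methyl on an aromatic nitrogen. With every measured value resting at the limit, the most that can be said is that a step beyond the usual scatter is not expected in this assay. The expected step is a number no higher from compound 1 to compound 4 (the limit leaves the size open). Compound 4 is estimated at 1000 10^-6 cm/s, within 300 10^-6 cm/s to 1500 10^-6 cm/s.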

Compound 4, apparent permeability: > 1000 10^-6 cm/s
Compound 4: a limit, no number; the forecaster's own chance of this, stated with the estimate: 55%; the middle value lies on the limit itself.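

No step can be read from compound 1 to compound 4, since both values are limits of the assay rather than numbers: the limit of > 1000 10^-6 cm/s in this assay, at which 4 of the 4 values shown sit.

The compounds shown leave open how far apart they truly lie in this assay, and whether 4-hydroxycyclohexyl in place of (oxolan-2-yl)methyl changes the read-out at all.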